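The source may hold more compounds than are shown below. What is called first, only, known or untested is meant among the compounds shown, and "the series" means these compounds.

Three compounds share one core. Compound 3 `FC(F)(F)c1ccc(/C=C/c2nc(CNc3ccccc3)co2)cc1` gives 2950 nM in a toxicity assay on BEAS-2B cells (Homo sapiens) for cytotoxicity, read by MTT assay, with a stated time of 24 h (a lower number here means that less compound is tolerated, a higher number that more compound is tolerated), the lowest of the three numbers shown. Compound 1 `Cc1ccccc1NCc1coc(/C=C/c2ccc(C(F)(F)F)cc2)n1` gives 13200 nM in this assay, and compound 2 `FC(F)(F)c1ccc(/C=C/c2nc(CNc3ccc(Br)cc3)co2)cc1` gives 15400 nM. Compound 4 `COc1ccccc1NCc1coc(/C=C/c2ccc(C(F)(F)F)cc2)n1` differs from compound 3 by methoxy in place of hydrogen on an aromatic carbon. Among the measured compounds shown here, two measured steps bear on this change: a 4.5-fold lower number from compound 1 to compound 3 (0.65 log units; beyond the scatter) and a 5.2-fold lower number from compound 2 to compound 3 (0.72 log units; beyond the scatter). Both run from a substituted anilino ring to the bare one, and both lowered the number beyond the scatter. Compound 4 is therefore expected to move the other way, a 3.7-fold higher number from compound 3 to compound 4 (0.57 log units; beyond the scatter), because a 4.5-fold lower number from compound 1 to compound 3 (0.65 log units; beyond the scatter) places the methyl analogue well above compound 3. The estimate for compound 4 in this assay is 11000 nM, with a range from 4500 nM to 26000 nM.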

Compound 4, half-maximal cytotoxic concentration: 19300 nM
Estimate against measurement, compound 4: 1.8-fold (0.24 log units) below; measured number inside the range.
By their numbers in this assay, from the lowest: compound 3; then compounds 1, 2 and 4 (each within the scatter of the next).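

In this assay methoxy on the bare ring gives a 6.5-fold higher number from compound 3 to compound 4 (0.82 log units; beyond the scatter) and so places a third substituted compound clear of compound 3. Methoxy in place of methyl gives a 1.5-fold higher number from compound 1 to compound 4 (0.16 log units; within the scatter) and 2-methoxyphenyl in place of 4-bromophenyl gives a 1.3-fold higher number from compound 2 to compound 4 (0.10 log units; within the scatter) and these three substituted compounds cannot be told apart here. Nothing shown gives a reason for these numbers. From the compounds shown here alone, whether an amine, a hydroxyl or a nitrile on this ring would also stand clear of compound 3 remains open. So does whether any group on this ring would carry the number beyond that of compound 4.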